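Boronic ester chalcones: cytotoxicity on a breast epithelial line

The source may report more compounds than this note shows. Statements on the series, on what has been measured and on what is new or still open speak of the compounds shown alone.

Measured compounds:
compound 1 `O=C(/C=C/c1ccc2c(c1)B(O)OC2)c1ccccc1`, 15900 nM
compound 2 `O=C(/C=C/c1ccc2c(c1)B(O)OC2)c1ccc(Br)cc1`, 27800 nM
compound 3 `O=C(/C=C/c1ccc2c(c1)B(O)OC2)c1ccccc1O`, 53700 nM

All three share the same core and differ only in the ring on the carbonyl carbon. In a toxicity assay on MCF-10A cells (Homo sapiens) for cytotoxicity, read by MTT assay, with a stated time of 48 h (a higher number here means a weaker inhibitor, a lower number a stronger inhibitor), compound 1 gives 15900 nM, the lowest of the three numbers. From there, two substitutions have been tried: a 1.7-fold higher number from compound 1 to compound 2 (0.24 log units; within the scatter) and a 3.4-fold higher number from compound 1 to compound 3 (0.53 log units; beyond the scatter). Between the two substituted compounds, a 1.9-fold higher number from compound 2 to compound 3 (0.29 log units; within the scatter).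

Compound 4 `Nc1cccc(C(=O)/C=C/c2ccc3c(c2)B(O)OC3)c1` is not yet measured. Relative to compound 1 it carries amino in place of hydrogen on an aromatic carbon.

Among the measured compounds shown here, no measured step puts an amino group on this ring, so the bearing steps are indirect. Both substitutions on compound 1, the bromo and the hydroxy, gave higher numbers, one within the scatter and one modestly beyond it. A further polar substituent on the same ring is therefore expected to move the number up rather than down, by a step no larger than the hydroxy case.

Compound 4 is estimated to give 25000 nM in this assay, within 10000 nM to 60000 nM, that is an expected 1.6-fold higher number from compound 1 to compound 4 (0.20 log units; within the scatter).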

Compound 4, half-maximal inhibitory concentration: 19600 nM
Estimate against measurement, compound 4: 1.3-fold (0.11 log units) above, within the range that was stated.
By their numbers in this assay, from the lowest: compounds 1, 4, 2 and 3 (each within the scatter of the next, the first and the last beyond it).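

Notes on the ring on the carbonyl carbon: in this assay, amino on an aromatic carbon, meta to a large group, gives a 1.2-fold higher number from compound 1 to compound 4 (0.09 log units; within the scatter), so compound 4 cannot be told apart from the parent compound 1. Among the compounds shown here, compound 4 is separated from the 2-hydroxyphenyl compound, with a 2.7-fold lower number from compound 3 to compound 4 (0.44 log units; beyond the scatter), but not from the 4-bromophenyl compound, with a 1.4-fold lower number from compound 2 to compound 4 (0.15 log units; within the scatter), leaving compound 3 as the only compound here with a step from compound 1 beyond the scatter. No measured evidence accounts for the gap between compound 3 and compound 4.

As far as these compounds go, compound 3 and compound 4 differ in both the group and its place on the ring, and which of these carries the gap stays open. From the compounds shown here alone, how a carboxylic acid or an acetamide on this ring would read in this assay also stays open.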